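Phenethyl to 4-fluorophenyl on sulfur, two cores compared

This account rests on a few compounds, and the source may have more. Where it says the series, first, only, none or still open, it means among the compounds named here.

Compound 1 `Nc1ccccc1NC(=O)/C=C/c1ccc(CSc2ccc(F)cc2)cc1` and compound 2 `Nc1ccccc1NC(=O)/C=C/c1ccc(CSCCc2ccccc2)cc1` share one core and differ only on a sulfur. In a functional assay on HCT-116 cells (Homo sapiens) for inhibition, read by CCK-8 assay, with a stated time of 72 h, tested at 8 uM (on this read-out lower numbers stand for less inhibition of growth and higher numbers for more inhibition of growth at the one concentration tested), compound 1 gives 20.2%, and in this assay compound 2 gives 10.6%. The change 4-fluorophenyl in place of phenethyl on a sulfur gave a number 9.6 percentage points higher from compound 2 to compound 1 (within the scatter), so these two values cannot be ordered. Compound 3 `Nc1ccccc1NC(=O)c1ccc(CSCCc2ccccc2)cc1` carries the phenethyl of compound 2 on a second core; the difference between the two cores is not broken down here. In this assay compound 3 gives 81.3%, the highest of the three and beyond the scatter from both of the others. Compound 4 `Nc1ccccc1NC(=O)c1ccc(CSc2ccc(F)cc2)cc1` is not yet measured; on the core of compound 3 it repeats the change (4-fluorophenyl in place of phenethyl on a sulfur), the same change as before, at the same kind of place. Since the earlier step of a number 9.6 percentage points higher from compound 2 to compound 1 (within the scatter) stayed within the scatter, the expected step of a number 1.3 percentage points lower from compound 3 to compound 4 (within the scatter) is likewise small. Resting on compound 3 at 81.3% and on that earlier step, compound 4 is expected to give 80%, with a range from 62% to 94%.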

Compound 4, percent growth inhibition at one concentration: 90.6%
The estimate for compound 4 lay 10.6 percentage points below the measured number; low and high end bracket the measured number.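

On the core of compound 3, 4-fluorophenyl in place of phenethyl on a sulfur gave a number 9.3 percentage points higher from compound 3 to compound 4 (within the scatter) in this assay. Set beside the step on the other core, the change carries over with no readable difference: the same change on two cores in this assay, a number 9.6 percentage points higher (within the scatter) from compound 2 to compound 1 and a number 9.3 percentage points higher (within the scatter) from compound 3 to compound 4, 0.3 percentage points apart, within the scatter of two such steps This agreement shows only that the swap left no readable step on either core at the one concentration tested; it does not order phenethyl and 4-fluorophenyl on either core, and it does not extend to any core beyond these two.

Open, from the compounds shown here alone, is whether other groups on the sulfur, such as a longer alkyl chain, a chain ending in an amine or one ending in a carboxylic acid, would also leave the number within the scatter on both cores. Also open, going by these compounds, is whether an oxygen in place of the sulfur would keep the number on the core of compound 3 at its level.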